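Swapping an Acid Side Chain for an Alcohol

The compounds below may be only part of what the source reports. "The series", "measured", "known", "first", "only" and "open" are said of these compounds alone.

compound 1 `CCCCC(=O)c1cc(C(CC)(CC)c2ccc(C#CC(O)(CC)CC)c(C)c2)cn1CC`: > 50 nM (a limit)
compound 2 `CCn1cc(C(CC)(CC)c2ccc(C#CC(O)(CC)CC)c(C)c2)cc1C(=O)N[C@@H](C(=O)O)C(C)C`: 68.3 nM

For the measured compounds named here, in an assay on cells for agonist activity at vitamin D3 receptor (Homo sapiens), read by microscopy (on this read-out lower numbers stand for an effect already at smaller amounts and higher numbers for an effect only at larger amounts of compound), compound 2 gives 68.3 nM, the only number obtained. For compound 1 this assay reports only (the limit of > 50 nM in this assay, at which 1 of the 2 values shown sits). The change from compound 1 to compound 2 is therefore a step that the limit leaves unreadable from compound 1 to compound 2. Compound 3 `CCn1cc(C(CC)(CC)c2ccc(C#CC(O)(CC)CC)c(C)c2)cc1C(=O)N[C@@H](C)CO` differs from compound 2 by 1-(hydroxymethyl)ethyl in place of 1-carboxy-2-methylpropyl on an amide-type nitrogen. Going by the values given here, no measured step covers this change, so no direction can be read from the data. The step from compound 2 to compound 3 is expected to be a 1.3-fold higher number from compound 2 to compound 3 (0.12 log units; within the scatter), within the scatter. Compound 3 is estimated at 90 nM, between 25 nM and 350 nM.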

Compound 3, half-maximal effective concentration: 7.33 nM
Compound 3: middle estimate off by 12-fold (1.09 log units), on the high side, and the stated range ends above it.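

On the amide-type nitrogen, the side chain clearly matters: in this assay, 1-(hydroxymethyl)ethyl in place of 1-carboxy-2-methylpropyl gives a 9.3-fold lower number from compound 2 to compound 3 (0.97 log units; beyond the scatter), a step beyond the usual scatter. Putting (1-(hydroxymethyl)ethyl)amino in place of butyl on the carbonyl carbon gives an at least 6.8-fold lower number from compound 1 to compound 3 (0.83 log units; beyond the scatter). Compound 1 is known only as a limit: the limit of > 50 nM in this assay, at which 1 of the 3 values shown sits.

The step to compound 3 replaces the carboxylic acid with an alcohol and also changes the size of the chain, so the compounds shown cannot separate these two changes. On these data alone, whether a 1-carboxyethyl group or an amine on the same nitrogen would behave like either side chain remains open.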